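A Dimethylphenyl Swap on the Sulfur of Compound 1

The compounds below may be only part of what the source reports. "The series", "measured", "known", "first", "only" and "open" are said of these compounds alone.

In a functional assay on HeLa cells (Homo sapiens) for antiproliferative activity, read by CCK-8 assay, with a stated time of 72 h (on this read-out lower numbers stand for stronger inhibition and higher numbers for weaker inhibition), compound 1 `COc1ccc(SCc2ccc(C(=O)Nc3ccccc3N)cc2)cc1` gives 2390 nM and compound 2 `COc1ccc(SCc2ccc(C(=O)Nc3ccccc3N)cc2)cc1OC` gives 3070 nM with the two values within the scatter of each other. For compound 3 `CC(C)(C)c1ccc(SCc2ccc(/C=C/C(=O)Nc3ccccc3N)cc2)cc1` the outcome is "not determined" (no result reported) and it therefore adds no number to the comparison. Compound 4 `Cc1cc(C)cc(SCc2ccc(C(=O)Nc3ccccc3N)cc2)c1` remains unmeasured and differs from compound 1 by 3,5-dimethylphenyl in place of 4-methoxyphenyl on a sulfur with 3,5-dimethylphenyl in place of 4-methoxyphenyl on a sulfur. Among the compounds with values here, the only measured step on this group, methoxy in place of hydrogen on an aromatic carbon, is a 1.3-fold higher number from compound 1 to compound 2 (0.11 log units; within the scatter) and offers limited guidance, since no measured compound carries dimethyl substitution. The expected change is a 1.1-fold higher number from compound 1 to compound 4 (0.04 log units; within the scatter) and no shift beyond the scatter is anticipated in this assay for this swap. Compound 4 is expected at 2600 nM within an estimated range of 1100 nM to 6000 nM on this evidence.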

Compound 4, half-maximal inhibitory concentration: 2090 nM
For compound 4 the middle estimate is 1.2-fold (0.09 log units) above the measured one; the measured number falls inside the stated range.
By their numbers in this assay, from the lowest: compounds 4, 1 and 2 (each within the scatter of the next).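

In this assay the swap on the sulfur gives a 1.1-fold lower number from compound 1 to compound 4 (0.06 log units; within the scatter) and so shows that this position accepts 3,5-dimethylphenyl in place of 4-methoxyphenyl without a change beyond the scatter. The earlier step only added a methoxy to the ring, whereas here the ring carries no oxygen and no hydrogen-bond acceptor, and the number still holds. No evidence is available to account for this result. The compounds shown leave open how this position would respond to an amine or a carboxylic acid on that ring, or to a longer chain on the sulfur.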